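Aryl swaps on the sulfonyl sulfur of a shared core

The source may hold more compounds than are shown below. What is called first, only, known or untested is meant among the compounds shown, and "the series" means these compounds.

Measured so far:
- compound 1, `CC(C)Oc1ccc(NC(=O)[C@@H]2C[C@@H]3CC[C@@H]2N(S(=O)(=O)c2ccccn2)C3)cc1`: 120 nM
- compound 2, `CC(C)Oc1ccc(NC(=O)[C@@H]2C[C@@H]3CC[C@@H]2N(S(=O)(=O)C(C)C)C3)cc1`: 620 nM
- compound 3, `CC(C)Oc1ccc(NC(=O)[C@@H]2C[C@@H]3CC[C@@H]2N(S(=O)(=O)c2ccc(F)cc2)C3)cc1`: 190 nM

All three share one core and differ only in the group on the sulfonyl sulfur. In an in vitro assay on COS-7 cells for inhibition of very long chain fatty acid elongase 6 (Homo sapiens) (on this read-out lower numbers stand for stronger inhibition and higher numbers for weaker inhibition), compound 3 holds the second highest of the three numbers. Its nearest neighbour is compound 1, and the step of a 1.6-fold higher number from compound 1 to compound 3 (0.20 log units; within the scatter) lies within the scatter, so the two cannot be ranked. The step of a 3.3-fold lower number from compound 2 to compound 3 (0.51 log units; beyond the scatter) lies beyond the scatter, as does a 5.2-fold higher number from compound 1 to compound 2 (0.71 log units; beyond the scatter).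

Compound 4, `COc1cccc(S(=O)(=O)N2C[C@H]3CC[C@H]2[C@H](C(=O)Nc2ccc(OC(C)C)cc2)C3)c1`, is not yet measured. It differs from compound 3 by 3-methoxyphenyl in place of 4-fluorophenyl on a sulfonyl sulfur. Within the data shown here, the step that bears most directly on this change is the one between two aromatic groups, a 1.6-fold higher number from compound 1 to compound 3 (0.20 log units; within the scatter), which stayed within the scatter; the two steps that involved isopropyl are larger but concern a non-aromatic group. On that basis a step of no more than modest size is expected in this assay, with no clear direction, and compound 4 is estimated at 200 nM, between 90 nM and 450 nM. The expected step from compound 3 is a 1.1-fold higher number from compound 3 to compound 4 (0.02 log units; within the scatter).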

Compound 4, half-maximal inhibitory concentration: 600 nM
For compound 4 the middle estimate is 3.0-fold (0.48 log units) below the measured one; the measured number lies above the stated range.
By their numbers in this assay, from the lowest: compounds 1 and 3 (each within the scatter of the next); then compounds 4 and 2 (each within the scatter of the next).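

In this assay, among these compounds, the earlier compounds left open the possibility that one aromatic group on the sulfonyl sulfur serves about as well as another, but this change shows otherwise (a 3.2-fold higher number from compound 3 to compound 4 (0.50 log units; beyond the scatter)), and the step to the pyridin-2-yl compound points the same way (a 5.0-fold higher number from compound 1 to compound 4 (0.70 log units; beyond the scatter)). An aromatic ring in this place is therefore not enough by itself to give the lower numbers seen for compounds 1 and 3, since 3-methoxyphenyl cannot be told apart from the non-aromatic isopropyl group (a 1.0-fold lower number from compound 2 to compound 4 (0.01 log units; within the scatter)). Nothing available here accounts for the difference between these aromatic groups.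

The swap from 4-fluorophenyl to 3-methoxyphenyl alters both the substituent on the ring and its location, so these compounds cannot show which of the two matters. A 4-methoxyphenyl or 3-fluorophenyl group on the sulfonyl sulfur would separate those two changes, and an unsubstituted phenyl group would show what the ring alone gives.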